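Sec-Butyl in Place of Hydrogen: Expected Solubility of Compound 4

This account rests on a few compounds, and the source may have more. Where it says the series, first, only, none or still open, it means among the compounds named here.

Compound 3 `COc1cc(NC(C)CCCN2C(=O)CN(C(=O)CN)C2(C)C)c2ncccc2c1` gives 150000 ug/mL in a physicochemical assay for solubility; a higher number here means a more soluble compound, a lower number a less soluble compound. Of the three measured compounds, compound 3 and compound 2 `COc1cc(NC(C)CCCN2C(=O)CN(C(=O)[C@@H](C)N)C2(C)C)c2ncccc2c1`, which gives 120000 ug/mL, stand together within the scatter, while compound 1 `COc1cc(NC(C)CCCN2C(=O)CN(C(=O)[C@H](N)CCSC)C2(C)C)c2ncccc2c1`, with 11700 ug/mL, stands apart: a 13-fold higher number from compound 1 to compound 3 (1.11 log units; beyond the scatter). Compound 4 `CC[C@H](C)[C@@H](N)C(=O)N1CC(=O)N(CCCC(C)Nc2cc(OC)cc3cccnc23)C1(C)C` differs from compound 3 by sec-butyl in place of hydrogen on a saturated chain carbon bound to an amine nitrogen and a carbonyl carbon. The step of a 1.3-fold higher number from compound 2 to compound 3 (0.10 log units; within the scatter) shows no difference beyond the scatter for a methyl at this carbon, whereas a 10-fold higher number from compound 1 to compound 2 (1.01 log units; beyond the scatter) and a 13-fold higher number from compound 1 to compound 3 (1.11 log units; beyond the scatter) are both large steps. Because the sec-butyl chain is larger than methyl and the step of a 13-fold higher number from compound 1 to compound 3 (1.11 log units; beyond the scatter) was large, compound 4 is expected to fall clearly below compound 3, estimated at 20000 ug/mL, within 6000 ug/mL to 60000 ug/mL, a step of a 7.5-fold lower number from compound 3 to compound 4 (0.88 log units; beyond the scatter).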

Compound 4, solubility: 29700 ug/mL
Estimate against measurement, compound 4: 1.5-fold (0.17 log units) below; low and high end bracket the measured number.
By their numbers in this assay, from the lowest: compound 1; then compound 4; then compounds 2 and 3 (each within the scatter of the next).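

In this assay, sec-butyl at this carbon brings a drop beyond the scatter (a 5.1-fold lower number from compound 3 to compound 4 (0.70 log units; beyond the scatter)) and also parts from methyl (a 4.0-fold lower number from compound 2 to compound 4 (0.61 log units; beyond the scatter)), whereas methyl showed no difference from hydrogen beyond the scatter. Sec-butyl and 2-(methylsulfanyl)ethyl also differ beyond the scatter (a 2.5-fold higher number from compound 1 to compound 4 (0.40 log units; beyond the scatter)), so the larger chains at this carbon do not land alike. Nothing available bears on the reason for these differences.

On these data alone, whether a carboxylic acid, a hydroxymethyl or a benzyl at this carbon would stay near hydrogen or fall with these chains remains open. As far as these compounds go, the opposite configuration at this carbon also remains open.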